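Changing the Sulfonyl Aryl Group in a Cytotoxicity Series

The source may hold more compounds than are shown below. What is called first, only, known or untested is meant among the compounds shown, and "the series" means these compounds.

In an ADME assay on HEK293 cells (Homo sapiens) for cytotoxicity, read by resazurin assay, with a stated time of 48 h (a higher number here means that more compound is tolerated, a lower number that less compound is tolerated), compound 1 (`Cc1ccccc1S(=O)(=O)Nc1ccc2oc(-c3ccccc3)nc2c1`) gives 57000 nM, compound 2 (`COc1cccc(S(=O)(=O)Nc2ccc3oc(-c4ccccc4)nc3c2)c1`) gives 63000 nM, and compound 3 (`O=S(=O)(Nc1ccc2oc(-c3ccccc3)nc2c1)c1ccccc1Cl`) gives 73000 nM. Compound 3 therefore stands within the scatter of both other compounds. Compound 4 (`CCc1ccc(S(=O)(=O)Nc2ccc3oc(-c4ccccc4)nc3c2)cc1`) has not yet been measured and differs from compound 3 at one place: 4-ethylphenyl in place of 2-chlorophenyl on a sulfonyl sulfur, with 4-ethylphenyl in place of 2-chlorophenyl on a sulfonyl sulfur. Within the data shown here, the three measured steps among the earlier compounds are all small: a 1.1-fold higher number from compound 1 to compound 2 (0.04 log units; within the scatter), a 1.3-fold higher number from compound 1 to compound 3 (0.11 log units; within the scatter) and a 1.2-fold higher number from compound 2 to compound 3 (0.06 log units; within the scatter). On that basis, no step beyond the scatter is expected in this assay. The estimate corresponds to a 1.1-fold lower number from compound 3 to compound 4 (0.05 log units; within the scatter). Compound 4 is expected at 65000 nM, within an estimated range of 32000 nM to 130000 nM.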

Compound 4, half-maximal cytotoxic concentration: 81000 nM
Compound 4: the middle estimate sits 1.2-fold (0.10 log units) below what was measured, and the stated range covers the measured number.
By their numbers in this assay, from the lowest: compounds 1, 2, 3 and 4 (each within the scatter of the next).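

The sulfonyl sulfur also accepts 4-ethylphenyl, a group of carbon only, with no step beyond the scatter (a 1.1-fold higher number from compound 3 to compound 4 (0.05 log units; within the scatter); a 1.3-fold higher number from compound 2 to compound 4 (0.11 log units; within the scatter); a 1.4-fold higher number from compound 1 to compound 4 (0.15 log units; within the scatter)). The four aryl groups now shown therefore all give numbers within the scatter of one another in this assay, and adding an ethyl-bearing group to the set does not break that picture.

From the compounds shown here alone, it remains open whether an aryl group carrying an amine or a carboxylic acid, or a longer chain in place of the ethyl, would stay within the scatter too. Nothing available explains why these numbers lie so close together.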